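The source may report more compounds than this note shows. Statements on the series, on what has been measured and on what is new or still open speak of the compounds shown alone.

Measured so far:
compound 1 `COc1ccc(C2CC(c3ccc(OCc4cn(Cc5ccc([N+](=O)[O-])cc5)nn4)cc3)=NN2C(C)=O)cc1`: 33%
compound 2 `COc1cc(C2CC(c3ccc([N+](=O)[O-])cc3)=NN2C(C)=O)ccc1OCc1cn(Cc2ccc([N+](=O)[O-])cc2)nn1`: 72%

In a functional assay on A549 cells (Homo sapiens) for inhibition, read by sulforhodamine B assay, tested at 100 uM (a higher number here means more inhibition of growth at the concentration tested, a lower number less inhibition of growth), compound 2 gives 72%, the higher of the two numbers at hand. Compound 1 gives 33% in this assay, a gap beyond the scatter. Going by the values given here, the two measured compounds differ from each other in more than one place, so neither single change is isolated by a measured pair, and the numbers say only that compound 2 stands clearly above compound 1.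

The next compound in the series is compound 3 `COc1cc(C2CC(c3ccccc3)=NN2C(C)=O)ccc1OCc1cn(Cc2ccc([N+](=O)[O-])cc2)nn1`. Relative to compound 2 the change is hydrogen in place of nitro on an aromatic carbon. Among the compounds with values here, no measured pair isolates this change, so the size of the step is unknown from the data. Given that compound 2 gives 72% and that the only other number in this assay lies well below it, a downward step of moderate size, beyond the scatter, is expected; the estimated step is a number 27 percentage points lower from compound 2 to compound 3 (beyond the scatter). Compound 3 is expected to give about 45%, with a range of 20% to 70%.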

Compound 3, percent growth inhibition at one concentration: 11%
Estimate against measurement, compound 3: 34 percentage points above; the measured number lies below the stated range.
By their numbers in this assay, from the lowest: compound 3; then compound 1; then compound 2.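

In this assay, going by these compounds alone, the change from 4-nitrophenyl to phenyl gives the first step that can be read from a measured pair that differs in one place (a number 61 percentage points lower from compound 2 to compound 3 (beyond the scatter)). This position is therefore not indifferent to what it carries: with the rest of compound 2 held constant, the presence of the nitro group on this aromatic carbon, para to a large group, goes with the higher growth inhibition, and its replacement by hydrogen removes most of it. The data at hand offer no measurement that explains why the number falls when the nitro group leaves.

As far as these compounds go, with only nitro and hydrogen compared at this place, it remains open whether the step is particular to nitro or whether another group there, such as an amine, a nitrile or a chlorine atom, would hold the number near that of compound 2. From the compounds shown here alone, it also remains open whether the same change would give a step of similar size elsewhere, since a single pair defines it.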